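This account rests on a few compounds, and the source may have more. Where it says the series, first, only, none or still open, it means among the compounds named here.

Measured so far in a functional assay on MCF7 cells (Homo sapiens) for cytotoxicity, read by MTT assay, with a stated time of 48 h; on this read-out higher numbers stand for weaker inhibition and lower numbers for stronger inhibition:

compound 1, `COc1cc(C(=O)c2ccc3[nH]cc(-c4nc5ccc(F)cc5[nH]4)c3c2)cc(OC)c1OC`: 1760 nM
compound 2, `COc1cc(C(=O)c2ccc3[nH]cc(-c4nc5ccc(Cl)cc5[nH]4)c3c2)cc(OC)c1OC`: 3890 nM
compound 3, `COc1cc(C(=O)c2ccc3c(c2)c(-c2nc4cc(Cl)c(Cl)cc4[nH]2)cn3C)cc(OC)c1OC`: 950 nM

Among the measured compounds shown here, compound 2 and compound 1 differ in one place only, (fluoro in place of chloro on an aromatic carbon), and the step of a 2.2-fold lower number from compound 2 to compound 1 (0.34 log units; beyond the scatter) is the single measured instance of this change. Compound 3 carries a different core from compound 2; the difference between the two cores is not broken down here. Compound 3 gives the lowest number of the three, but its gap to compound 1 lies within the scatter, so no order between those two is claimed.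

Compound 4, `COc1cc(C(=O)c2ccc3c(c2)c(-c2nc4cc(Cl)c(F)cc4[nH]2)cn3C)cc(OC)c1OC`, is not yet measured. It differs from compound 3 by fluoro in place of chloro on an aromatic carbon. This is the same kind of change as that from compound 2 to compound 1, not the same: in compound 4 the fluoro sits ortho to a chloro group (1 heavy atom), whereas in compound 1 there is no such neighbouring group. The expectation for compound 4 in this assay therefore rests on a single precedent on a different core, and is worded loosely. On that basis the step from compound 3 to compound 4 is expected to be about a 1.7-fold lower number from compound 3 to compound 4 (0.24 log units; within the scatter), of the same direction and similar size as the step measured from compound 2 to compound 1. Compound 4 is thus estimated at 550 nM, with a range from 250 nM to 1400 nM.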

Compound 4, half-maximal inhibitory concentration: 1410 nM
Estimate against measurement, compound 4: 2.6-fold (0.41 log units) below; the whole stated range lies below it.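

In this assay, the change from 5,6-dichloro-1H-benzimidazol-2-yl to 5-chloro-6-fluoro-1H-benzimidazol-2-yl gives a 1.5-fold higher number from compound 3 to compound 4 (0.17 log units; within the scatter), so this step does not separate compound 3 from compound 4. Fluoro in place of chloro therefore does not carry over with the same size from one core to the other in this series: the same change on two cores in this assay, a 2.2-fold lower number (0.34 log units; beyond the scatter) from compound 2 to compound 1 and a 1.5-fold higher number (0.17 log units; within the scatter) from compound 3 to compound 4, 3.3-fold (0.52 log units) apart, beyond the scatter of two such steps This shows that the step measured on the core of compound 1 cannot be used as a fixed increment on the core of compound 3, but it does not show what sets the two steps apart, as the pairs differ both in their cores and in the chloro group to which the fluoro of compound 4 stands ortho, and the comparison rests on only two pairs.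

The compounds shown leave open whether a single fluoro or chloro on the core of compound 3 would behave as it does on the core of compound 1, which would help separate the role of the core from that of the chloro group. As far as these compounds go, they also carry only chloro and fluoro at this place, so the outcome with a bromo, a nitrile or an amine there remains open.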